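This account rests on a few compounds, and the source may have more. Where it says the series, first, only, none or still open, it means among the compounds named here.

Compound 1 `COc1ccc(-c2ccc(-c3ccc(C(=N)N)o3)o2)cc1` is one of three amidines measured in a functional assay on Hs-578T cells (Homo sapiens) for inhibition, read by sulforhodamine B assay, with a stated time of 48 h; a higher number here means a weaker inhibitor of growth, a lower number a stronger inhibitor of growth. In this assay compound 1 gives 4330 nM. For the measured compounds named here, compound 3 `COc1cc(OC)cc(-c2ccc(-c3ccc(C(=N)N)o3)o2)c1` carries two methoxy groups on its terminal ring, and in this assay compound 3 gives 8120 nM, a number within the scatter of the one for compound 1. Compound 2 `N=C(N)c1ccc(-c2ccc(-c3cncc4ccccc34)s2)s1`, built on a different core, gives 2220 nM in this assay, again within the scatter of compound 1. Compound 1 therefore stands second highest of the three numbers, yet neither of the other two is separated from it beyond the scatter, so no order among them can be read.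

Compound 4 `N=C(N)c1ccc(-c2ccc(-c3ccccc3)o2)o1` is the next compound to be measured in this assay. It differs from compound 1 in a single place: hydrogen in place of methoxy on an aromatic carbon. Going by the values given here, no measured pair differs by this same change, so no measured step can be carried across. What the values of compound 1 and compound 3 show is only that the presence of one or two methoxy groups on that ring did not move the number beyond the scatter. On this basis the step from compound 1 to compound 4 is expected to be a 1.0-fold lower number from compound 1 to compound 4 (0.00 log units; within the scatter), that is no change beyond the scatter in either direction. Compound 4 is thus estimated to give 4300 nM in this assay, within a range of 1800 nM to 10000 nM.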

Compound 4, concentration for 50% growth inhibition: 3810 nM
The estimate for compound 4 lay 1.1-fold (0.05 log units) above the measured number; the range from low to high includes it.
By their numbers in this assay, from the lowest: compounds 2, 4, 1 and 3 (each within the scatter of the next, the first and the last beyond it).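

In this assay, for the compounds shown here, the replacement of methoxy by hydrogen on an aromatic carbon, para to a large group, gives a 1.1-fold lower number from compound 1 to compound 4 (0.06 log units; within the scatter) and is the first measured step between two compounds that differ in one place. It shows that, on the core of compound 1, the number stays within the scatter when this position carries no methoxy at all, so the methoxy group is not required for a growth-inhibition number of this size in this cell line. Nothing presented gives a reason for this lack of change, and the step alone cannot supply one.

What the compounds shown leave open is whether this position tolerates any group or only these two, since an amine, a carboxylic acid, a chlorine atom or a longer chain such as butoxy in the same place could move the number beyond the scatter or leave it within it. On these data alone, it also remains open whether hydrogen in place of methoxy would give a step of the same size on a different core, such as that of compound 2, which carries no methoxy group.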